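The source may hold more compounds than are shown below. What is called first, only, known or untested is meant among the compounds shown, and "the series" means these compounds.

compound 1 (`CCOc1cc(C(C)(C)C)ccc1C1=NC(c2ccc(Cl)cc2)C(c2ccc(Cl)cc2)N1C(=O)NCCCCCCCC(=O)Nc1ccccc1N`): 20300 nM
compound 2 (`CCOc1cc(C(C)(C)C)ccc1C1=NC(c2ccc(Cl)cc2)C(c2ccc(Cl)cc2)N1C(=O)N1CCN(CCCCCC(=O)NO)CC1`): 7260 nM

In a functional assay on MCF7 cells (Homo sapiens) for antiproliferative activity, read by CCK-8 assay, with a stated time of 72 h (a lower number here means a stronger inhibitor, a higher number a weaker inhibitor), compound 1 has the higher of the two numbers, which makes it the weaker inhibitor, and compound 2 lies lower by more than the usual scatter. Compound 3 (`CCOc1cc(C(C)(C)C)ccc1C1=NC(c2ccc(Cl)cc2)C(c2ccc(Cl)cc2)N1C(=O)NCCCCCCCC(=O)NO`) leaves the rest of compound 1 unchanged and differs at one place: hydroxy in place of 2-aminophenyl on an amide-type nitrogen. Compound 2 also carries hydroxycarbamoyl and gives 7260 nM, so a moderate fall beyond the scatter is expected in this assay. The expected change is a 2.9-fold lower number from compound 1 to compound 3 (0.46 log units; beyond the scatter). Compound 3 is estimated at 7000 nM, with an expected range of 2000 nM to 20000 nM.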

Compound 3, half-maximal inhibitory concentration: 7920 nM
Beside the measured number, compound 3's estimate is 1.1-fold (0.05 log units) below it; low and high end bracket the measured number.
By their numbers in this assay, from the lowest: compounds 2 and 3 (each within the scatter of the next); then compound 1.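

In this assay, putting hydroxy in place of 2-aminophenyl on the amide-type nitrogen gives a 2.6-fold lower number from compound 1 to compound 3 (0.41 log units; beyond the scatter) and leaves the rest of compound 1 unchanged. Among the compounds shown here, this is the first comparison here that isolates a single change, and it shows that this end group alone can move the number beyond the scatter. The step is modest, and compound 3 remains in the same range as compound 2 on the printed values.

From the compounds shown here alone, how a methoxy or a carboxylic acid at this end would read remains open, as does the effect of a shorter or longer chain. Nothing measured here gives a reason for the step.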